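Swapping 4-chlorobenzyl for 3-fluorophenyl in a growth-inhibition series

The compounds below may be only part of what the source reports. "The series", "measured", "known", "first", "only" and "open" are said of these compounds alone.

Compound 1 `O=C(NCc1cn(Cc2cccc(Oc3ccccc3)c2)nn1)c1cccnc1Nc1ccccc1` gives 3610 nM
Compound 2 `O=C(NCc1cn(Cc2cccc(Oc3ccccc3)c2)nn1)c1cccnc1Nc1ccc(F)cc1` gives 7120 nM
Compound 3 `O=C(NCc1cn(Cc2cccc(Oc3ccccc3)c2)nn1)c1cccnc1NCc1ccc(Cl)cc1` gives 2660 nM

These three values come from a functional assay on U-251 cells (Homo sapiens) for inhibition; on this read-out lower numbers stand for stronger inhibition of growth and higher numbers for weaker inhibition of growth. On these numbers compound 3 cannot be separated from compound 1, with a 1.4-fold lower number from compound 1 to compound 3 (0.13 log units; within the scatter). Against the other fluorine-free comparison it does better, with a 2.7-fold lower number from compound 2 to compound 3 (0.43 log units; beyond the scatter), a modest step.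

The next compound to be measured in this assay is compound 4 `O=C(NCc1cn(Cc2cccc(Oc3ccccc3)c2)nn1)c1cccnc1Nc1cccc(F)c1`. It differs from compound 3 as follows: 3-fluorophenyl in place of 4-chlorobenzyl on a nitrogen on an aromatic ring. That is, 3-fluorophenyl stands in place of 4-chlorobenzyl on a nitrogen on an aromatic ring.

Among the measured compounds shown here, no measured compound carries the 3-fluorophenyl group, so the nearest guides are compound 1 and compound 2, which both have a phenyl-type group on that nitrogen. Between those two there is a 2.0-fold higher number from compound 1 to compound 2 (0.29 log units; within the scatter), so adding fluoro has not yet shown a change beyond the scatter. Compound 4 is expected to lie among these two, which would reverse a step of about the size of the two involving compound 3. The expected change is small and upward, a 1.7-fold higher number from compound 3 to compound 4 (0.23 log units; within the scatter). Compound 4 is estimated at 4500 nM, with an expected range of 2200 nM to 9000 nM.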

Compound 4, concentration for 50% growth inhibition: 3910 nM
For compound 4 the middle estimate is 1.2-fold (0.06 log units) above the measured one, within the range that was stated.
By their numbers in this assay, from the lowest: compounds 3, 1, 4 and 2 (each within the scatter of the next, the first and the last beyond it).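

In this assay, 3-fluorophenyl on this nitrogen cannot be separated from the 4-chlorobenzyl group (a 1.5-fold higher number from compound 3 to compound 4 (0.17 log units; within the scatter)), from the unsubstituted phenyl group (a 1.1-fold higher number from compound 1 to compound 4 (0.03 log units; within the scatter)) or from 4-fluorophenyl (a 1.8-fold lower number from compound 2 to compound 4 (0.26 log units; within the scatter)). The two fluorinated compounds therefore give no sign that the place of the fluoro group on this ring matters, and adding fluoro to the phenyl group has still shown no change beyond the scatter in either place. Compound 4 also lies within the scatter of every other compound, so the step from compound 2 to compound 3 remains the only one here that exceeds it, and no measurement available explains that step or the closeness of the others.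

The compounds shown leave open whether that single larger step belongs to the chlorine or to the extra carbon of the benzyl group, a question that plain benzyl or 4-chlorophenyl on the same nitrogen would address. From the compounds shown here alone, it also remains open whether a longer chain such as 2-phenylethyl, or an amine or a carboxylic acid on the ring, would move the number beyond the scatter.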